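Removing a Ring Methyl: Solubility Across Two Cores

The compounds below may be only part of what the source reports. "The series", "measured", "known", "first", "only" and "open" are said of these compounds alone.

Compound 1 `CN1CCN(c2cnc3[nH]cc(-c4cccc(C#N)c4)c3c2)CC1` and compound 2 `N#Cc1cccc(-c2c[nH]c3ncc(N4CCNCC4)cc23)c1` share one core, while compound 3 `CN1CCC(n2cc(-c3cnc4[nH]cc(-c5cccc(C#N)c5)c4c3)cn2)CC1` and compound 4 `N#Cc1cccc(-c2c[nH]c3ncc(-c4cnn(C5CCNCC5)c4)cc23)c1` share another; the difference between the two cores is not broken down here. In a physicochemical assay for solubility, read by LC-MS, in phosphate buffer, measured as thermodynamic solubility, with a stated time of 24 h, at pH 7.4 (on this read-out higher numbers stand for higher solubility and lower numbers for lower solubility), compound 1 gives 230000 nM and compound 2 gives 240000 nM, so the change hydrogen in place of methyl on an amine nitrogen in a ring made a step of a 1.0-fold higher number from compound 1 to compound 2 (0.02 log units; within the scatter), which lies within the usual scatter. In this assay compound 3 gives 3800 nM, the lowest of the three measured numbers and beyond the scatter from both compound 1 and compound 2.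

The change from compound 3 to compound 4 is hydrogen in place of methyl on an amine nitrogen in a ring, the same kind of change as from compound 1 to compound 2, though the ring there holds 2 nitrogen and sits three ring bonds from the ring nitrogen, whereas here the ring holds 1 nitrogen. Because the step of a 1.0-fold higher number from compound 1 to compound 2 (0.02 log units; within the scatter) stayed within the scatter, a step of about a 1.1-fold higher number from compound 3 to compound 4 (0.02 log units; within the scatter) is expected in this assay for compound 4. Compound 4 is therefore estimated at 4000 nM in this assay, with a likely range from 1500 nM to 12000 nM.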

Compound 4, solubility: 25000 nM
For compound 4 the middle estimate is 6.3-fold (0.80 log units) below the measured one; measured number above the stated range.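

In this assay, the change from 1-methylpiperidin-4-yl to piperidin-4-yl gave a 6.6-fold higher number from compound 3 to compound 4 (0.82 log units; beyond the scatter), whereas the same kind of change on the other core gave a 1.0-fold higher number from compound 1 to compound 2 (0.02 log units; within the scatter), so the size of the step did not carry over from one pair to the other. This shows that, within this series, a methyl-to-hydrogen step that lies within the scatter in one setting can lie beyond it in another; it does not show whether the core or the ring holding the amine nitrogen sets the difference, as the two pairs differ in both, and each setting rests on a single pair. Nothing available here explains the gap between the two steps.

Going by these compounds, it remains open how an ethyl group or an acetyl group in place of the methyl on that amine nitrogen would read out on either core. Also open, on these data alone, is whether a carboxylic acid or a primary amine on the piperidin-4-yl ring would give a step like that to compound 4.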